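The compounds below may be only part of what the source reports. "The series", "measured", "known", "first", "only" and "open" are said of these compounds alone.

Compound 1, `Cc1nc2ccc(Br)cc2c(=O)n1NCc1nnc(N2C(=O)CSC2c2ccc(O)cc2)s1`, gives 60% in a functional assay on the whole organism (strain albino) with Rattus norvegicus as the target, in the maximal electroshock model, with a stated time of 1 h, at a dose of 30 mg/kg by the intraperitoneal route; a higher number here means more inhibition at the dose given (going by the name of the read-out), a lower number less inhibition. Compound 2, `Cc1nc2ccccc2c(=O)n1NCc1nnc(N2C(=O)CSC2c2ccc(O)cc2)s1`, gives 60% in this assay. Compound 3, `Cc1nc2ccccc2c(=O)n1NCC(=O)NNC(N)=S`, gives 30% in this assay.

Compound 4, `Cc1nc2ccc(Br)cc2c(=O)n1NCC(=O)NNC(N)=S`, has not yet been measured in this assay. Compound 4 is built on the core of compound 3, and the difference between that core and the shared core of compounds 1 and 2 is not broken down here. Among the three measured compounds, compound 3 stands lowest, with its steps to compound 1 and to compound 2 both beyond the scatter.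

The change that turns compound 3 into compound 4 is bromo in place of hydrogen on an aromatic carbon. It occurs twice among these compounds: the same change, at the same place, turns compound 2 into compound 1, where it is bromo in place of hydrogen on an aromatic carbon and gave no change at the digits printed from compound 2 to compound 1 (within the scatter). Because that earlier step was no change at the digits printed from compound 2 to compound 1 (within the scatter), a step of similar size is expected in this assay from compound 3 to compound 4, namely no change at the digits printed from compound 3 to compound 4 (within the scatter). Compound 4 is therefore estimated at 30%, with a likely range from 10% to 50%.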

Compound 4, a percentage reported as inhibition, in the whole organism at one dose (the size of the read-out at that dose, not a potency): 30%
The estimate for compound 4 equals the measured number at the digits printed; low and high end bracket the measured number.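

In this assay, bromo in place of hydrogen on an aromatic carbon gave no change at the digits printed from compound 3 to compound 4 (within the scatter), and this step agrees with the one seen earlier on the other core: the same change on two cores in this assay, no change at the digits printed (within the scatter) from compound 2 to compound 1 and no change at the digits printed (within the scatter) from compound 3 to compound 4, 0 percentage points apart, within the scatter of two such steps. Within this series, then, the change carries from one core to the other, and on neither core does it shift the percentage inhibition beyond the usual scatter. Among the compounds shown here, this rests on only two cores and on a read-out taken at a single dose and a single time, so it does not show that the change would be equally silent on a third core, at another dose or at another time, and it says nothing about why the step is so small.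

The compounds shown leave open whether another group on that same aromatic carbon, such as chloro, methoxy or an amine, would also leave the read-out in place on both cores. They also leave open what bromo would do on a different carbon of that ring.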